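The source may hold more compounds than are shown below. What is called first, only, known or untested is meant among the compounds shown, and "the series" means these compounds.

Among the measured compounds shown here, compound 2 `Cc1ccc(OC2CCN(c3ccc(-n4ccnc4)nn3)CC2)cc1` gives 527 nM in an assay on microsomes from liver for inhibition of acyl-CoA desaturase 1 (Rattus norvegicus) (a lower number here means a stronger inhibitor, a higher number a weaker inhibitor), the highest of the two numbers measured so far; its nearest neighbour is compound 1 `Brc1ccccc1OC1CCN(c2ccc(-n3ccnc3)nn2)CC1`, which gives 5 nM. For the measured compounds named here, the single step with a measurement, a 110-fold higher number from compound 1 to compound 2 (2.02 log units; beyond the scatter), shows that the group on the oxygen on the saturated carbon matters a great deal. Compound 3 `Cc1cccc(OC2CCN(c3ccc(-n4ccnc4)nn3)CC2)c1` has not yet been measured; it differs from compound 2 only by 3-methylphenyl in place of 4-methylphenyl on an oxygen on a saturated carbon. Going by the values given here, no measured step here moves a methyl from one place on that phenyl to another, so the size of the change can only be guessed from the sensitivity that the step from compound 1 to compound 2 revealed. Compound 3 is expected to land somewhere between the two measured numbers, with an estimated step of a 2.6-fold lower number from compound 2 to compound 3 (0.42 log units; beyond the scatter) relative to compound 2. The estimated value for compound 3 is 200 nM, within a range from 40 nM to 1200 nM.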

Compound 3, half-maximal inhibitory concentration: 251 nM
Compound 3: the middle estimate sits 1.3-fold (0.10 log units) below what was measured; low and high end bracket the measured number.
By their numbers in this assay, from the lowest: compound 1; then compound 3; then compound 2.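

Moving the methyl from 4-methylphenyl to 3-methylphenyl keeps the same atoms on the oxygen, yet this assay shows a 2.1-fold lower number from compound 2 to compound 3 (0.32 log units; beyond the scatter), a modest change but one beyond the scatter. The place of a methyl on this phenyl therefore has a measurable effect on its own, though that effect is small beside a 50-fold higher number from compound 1 to compound 3 (1.70 log units; beyond the scatter), which leaves 3-methylphenyl still far from 2-bromophenyl. Nothing available explains either step.

Compound 1 and compound 3 differ both in the atom on the phenyl and in where it sits, so it remains open which of the two accounts for the low number of compound 1. Placing 2-methylphenyl or 3-bromophenyl on the same oxygen would pull these two apart, and 3-aminophenyl would show how an amine fares there.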